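A few compounds are considered here, and "the series" means these few. Any claim that something is new, unique, unknown or untested is made for them only; others in the source may bear on it.

Compound 1 `Nc1ccc(C(=O)N/N=C/c2cccc([N+](=O)[O-])c2)cc1` gives 2.6 in a physicochemical assay for lipophilicity; a higher number here means a more lipophilic compound, a lower number a more polar compound. Compound 2 `O=C(N/N=C/c1cccc([N+](=O)[O-])c1)c1ccccc1Br` carries 2-bromophenyl in place of 4-aminophenyl on a carbonyl carbon, and in this assay compound 2 gives 4.17, which makes a number 1.57 log units higher from compound 1 to compound 2 (beyond the scatter). Compound 3 `COc1ccc(/C=N/NC(=O)c2ccc(N)cc2)cc1OC` gives 2.14 in this assay, the lowest of the three measured values; how its core differs from that of compound 1 is not broken down here. Compound 4 `COc1ccc(/C=N/NC(=O)c2ccccc2Br)cc1OC` has not yet been measured in this assay. Within the data shown here, it carries 2-bromophenyl in place of 4-aminophenyl on a carbonyl carbon, the same change as the one made from compound 1 to compound 2, at an identically described place. Because that change produced a number 1.57 log units higher from compound 1 to compound 2 (beyond the scatter), a step of similar size is expected here. The step expected is a number 1.57 log units higher from compound 3 to compound 4 (beyond the scatter). Compound 4 is thus estimated at 3.71, with a likely range from 3.3 to 4.1.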

Compound 4, partition coefficient: 3.71
Estimate against measurement, compound 4: no gap at the digits printed; low and high end bracket the measured number.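

In this assay, 2-bromophenyl in place of 4-aminophenyl on a carbonyl carbon gives a number 1.57 log units higher from compound 3 to compound 4 (beyond the scatter) and on the other core gives a number 1.57 log units higher from compound 1 to compound 2 (beyond the scatter) at the same size, so the step carried over unchanged between these two cores. This is a single repeat across two cores, which shows that the step held here but not that it would hold on any other core in the series. Nothing at hand accounts for why the two steps agree.

The compounds shown leave open how a plain phenyl, a chlorophenyl or a benzoic acid would compare on a carbonyl carbon whose other neighbour is the amide-type nitrogen. They also leave open whether the step would persist on a core carrying a carboxylic acid or a longer alkyl chain.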